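The compounds below may be only part of what the source reports. "The series", "measured", "known", "first", "only" and "open" are said of these compounds alone.

Measured compounds:
Compound 1, `CC/C=C\C(=O)Nc1cc(Nc2nc3c(c(-c4cn(C)c5ccc(F)cc45)n2)CSCC3)c(OC)cc1N(C)CCN(C)C`: in a functional assay on A549 cells (Homo sapiens) for inhibition, read by MTT assay, with a stated time of 72 h (a higher number here means a weaker inhibitor, a lower number a stronger inhibitor), compound 1 gives 1450 nM.
Compound 2, `CC/C=C\C(=O)Nc1cc(Nc2nc3c(c(-c4cn(C)c5ccccc45)n2)CSCC3)c(OC)cc1N(C)CCN(C)C`: in this assay compound 2 gives 236 nM.
Compound 3, `C=CC(=O)Nc1cc(Nc2nc3c(c(-c4cn(C)c5ccccc45)n2)CS(=O)(=O)CC3)c(OC)cc1N(C)CCN(C)C`: in this assay compound 3 gives 8690 nM.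

Compound 4, `C=CC(=O)Nc1cc(Nc2nc3c(c(-c4cn(C)c5ccc(F)cc45)n2)CS(=O)(=O)CC3)c(OC)cc1N(C)CCN(C)C`, has not yet been measured. Of the three measured compounds, compound 3 carries the highest number. The difference between the cores of compound 2 and compound 3 is not broken down here. Compound 1 differs from compound 2 by fluoro in place of hydrogen on an aromatic carbon, and that step was a 6.1-fold higher number from compound 2 to compound 1 (0.79 log units; beyond the scatter). Compound 4 differs from compound 3 by fluoro in place of hydrogen on an aromatic carbon, the same change. It occurs only twice among these compounds, so one measured step is the sole guide. In this assay the step expected is a 4.6-fold higher number from compound 3 to compound 4 (0.66 log units; beyond the scatter), resting on the measured step of a 6.1-fold higher number from compound 2 to compound 1 (0.79 log units; beyond the scatter). For compound 4 the estimate is 40000 nM, expected to lie between 12000 nM and 130000 nM.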

Compound 4, half-maximal inhibitory concentration: 4640 nM
Estimate against measurement, compound 4: 8.6-fold (0.94 log units) above; the measured number lies below the stated range.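

In this assay, replacing 1-methyl-1H-indol-3-yl with 5-fluoro-1-methyl-1H-indol-3-yl on the core of compound 3 gives a 1.9-fold lower number from compound 3 to compound 4 (0.27 log units; within the scatter). The fluoro change therefore did not carry over as a fixed step between these two cores: the same change on two cores in this assay, a 6.1-fold higher number (0.79 log units; beyond the scatter) from compound 2 to compound 1 and a 1.9-fold lower number (0.27 log units; within the scatter) from compound 3 to compound 4, 12-fold (1.06 log units) apart, beyond the scatter of two such steps. Among these compounds, this shows that, in these two pairs, the step depends on the core, but it rests on only two steps, and the cores differ in more than one place, so it does not show which difference is responsible.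

The compounds shown leave open which part of the core governs the step. They also leave open whether a chloro or methoxy group at the same position would follow the fluoro steps on both cores.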